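Removing one trifluoromethyl from the urea aryl ring of compound 3

This account rests on a few compounds, and the source may have more. Where it says the series, first, only, none or still open, it means among the compounds named here.

Within the data shown here, the series shares one core carrying an aryl urea, and the three measured members differ in the groups on the outer aryl ring of the urea and in one group on the core. Compound 1 `O=C(Nc1cccc(-n2cc(-c3ccncc3)c(-c3cc(O)cc(Cl)c3)n2)c1)Nc1ccc(Cl)c(C(F)(F)F)c1` in a functional assay on RXF 393 cells (Homo sapiens) for inhibition, read by sulforhodamine B assay, with a stated time of 48 h, tested at 0.01 uM (on this read-out higher numbers stand for a weaker effect at the one concentration tested and lower numbers for a stronger effect), gives 93%. Compound 2 `O=C(Nc1cccc(-n2cc(-c3ccncc3)c(-c3cc(O)cc(Cl)c3)n2)c1)Nc1ccc(Cl)c(Cl)c1` gives 93% in this assay. Among the measured compounds shown here, the single one-place step between measured compounds, no change at the digits printed from compound 1 to compound 2 (within the scatter), left the read-out where it was. Compound 3 `COc1cc(Cl)cc(-c2nn(-c3cccc(NC(=O)Nc4cc(C(F)(F)F)cc(C(F)(F)F)c4)c3)cc2-c2ccncc2)c1` gives 96% in this assay; this is the highest of the three numbers, but it sits within the scatter of both compound 1 and compound 2, so the three cannot be ordered.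

Compound 4 `COc1cc(Cl)cc(-c2nn(-c3cccc(NC(=O)Nc4cccc(C(F)(F)F)c4)c3)cc2-c2ccncc2)c1` differs from compound 3 in one place: hydrogen in place of trifluoromethyl on an aromatic carbon. For the measured compounds named here, the only measured step that bears on this site is the exchange of one group for another on the same urea aryl ring, and that step did not move the read-out. Going by the values given here, no measured step removes a group from this ring altogether, so the comparison is indirect. On that basis the step of a number 2 percentage points lower from compound 3 to compound 4 (within the scatter) is expected to stay within the scatter. Compound 4 is therefore estimated at 94% in this assay, in a range from 84% to 100%.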

Compound 4, a percentage reported as activity, at one concentration (the size of the read-out at that concentration, not a potency): 93%
Beside the measured number, compound 4's estimate is 1 percentage points above it; low and high end bracket the measured number.
By their numbers in this assay, from the lowest: compounds 1, 2, 4 and 3 (each within the scatter of the next).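

In this assay, the loss of one trifluoromethyl, with hydrogen entering on the aromatic carbon, appears as a number 3 percentage points lower from compound 3 to compound 4 (within the scatter). This step goes beyond the earlier exchange of one group for another on the urea aryl ring: here a group of 4 heavy atoms is removed outright, with one trifluoromethyl still on the ring, and the read-out at this single concentration gives no sign of a difference. Nothing available accounts for this outcome at the position.

Open questions are whether the ring would tolerate the loss of the remaining trifluoromethyl from compound 4, and whether a polar replacement such as an amine or a carboxylic acid at the vacated carbon would shift the read-out. Because every compound shown sits within the scatter of the others at one concentration, these notes also leave open whether this position would look equally insensitive at a higher concentration or in a potency measurement.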